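Amine variation in the bis-trifluoromethyl benzyl ether series

A few compounds are considered here, and "the series" means these few. Any claim that something is new, unique, unknown or untested is made for them only; others in the source may bear on it.

Among the compounds with values here, compound 3 `FC(F)(F)c1cc(COCC2(c3ccccc3)CCC(NC3CC3)CC2)cc(C(F)(F)F)c1` gives 74 nM in an assay on isolated protein for antagonist activity at Substance-P receptor (Homo sapiens) (on this read-out higher numbers stand for weaker inhibition and lower numbers for stronger inhibition), the second highest of the three numbers so far. Compound 1 `CCN(CC)C1CCC(COCc2cc(C(F)(F)F)cc(C(F)(F)F)c2)(c2ccccc2)CC1` gives 38 nM and compound 2 `CN1CCN(C2CCC(COCc3cc(C(F)(F)F)cc(C(F)(F)F)c3)(c3ccccc3)CC2)CC1` gives 120 nM; of the steps, only a 3.2-fold higher number from compound 1 to compound 2 (0.50 log units; beyond the scatter) lies beyond the scatter, whereas a 1.9-fold higher number from compound 1 to compound 3 (0.29 log units; within the scatter) and a 1.6-fold lower number from compound 2 to compound 3 (0.21 log units; within the scatter) do not. Compound 4 `CCNC1CCC(COCc2cc(C(F)(F)F)cc(C(F)(F)F)c2)(c2ccccc2)CC1` carries ethyl in place of cyclopropyl on an amine nitrogen. Within the data shown here, no measured pair exchanges one small substituent on a secondary amine for another; the closest bearing, the diethylamino to cyclopropylamino step, was within the scatter. A step within the scatter is therefore expected in this assay, a 1.2-fold lower number from compound 3 to compound 4 (0.09 log units; within the scatter). Compound 4 is estimated at 60 nM, with a range from 25 nM to 150 nM.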

Compound 4, half-maximal inhibitory concentration: 14 nM
Estimate against measurement, compound 4: 4.3-fold (0.63 log units) above; the measured number lies below the stated range.
By their numbers in this assay, from the lowest: compound 4; then compounds 1, 3 and 2 (each within the scatter of the next, the first and the last beyond it).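

In this assay, the identity of a small group on this amine nitrogen matters: ethyl in place of cyclopropyl gives a 5.3-fold lower number from compound 3 to compound 4 (0.72 log units; beyond the scatter) and separates two groups that the earlier steps gave no reason to tell apart. Compound 4 also stands beyond the scatter of the other two amines, with a 2.7-fold lower number from compound 1 to compound 4 (0.43 log units; beyond the scatter) on loss of one ethyl and an 8.6-fold lower number from compound 2 to compound 4 (0.93 log units; beyond the scatter) against 4-methylpiperazin-1-yl. Nothing at hand accounts for these differences. Open, going by these compounds, is whether a propyl or isopropyl group on this nitrogen, or the unsubstituted primary amine, holds this level.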